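Bromophenyl Amide in Place of the Methoxyphenyl Analogue

The compounds below may be only part of what the source reports. "The series", "measured", "known", "first", "only" and "open" are said of these compounds alone.

Compound 3 `COc1cccc(NC(=O)CSc2nc(Nc3ccccc3)c3ccccc3n2)c1` bears the 3-methoxyphenyl amide and, in a functional assay on NCI-H1975 cells (Homo sapiens) for inhibition, read by MTT assay, with a stated time of 72 h (a lower number here means a stronger inhibitor, a higher number a weaker inhibitor), compound 3 gives 19400 nM, the highest number among the three measured compounds. Compound 1 `O=C(CSc1nc(Nc2ccccc2)c2ccccc2n1)Nc1ccccc1Cl` gives 9610 nM and compound 2 `O=C(CSc1nc(Nc2ccccc2)c2ccccc2n1)Nc1ccccc1Br` gives 10300 nM in this assay; the steps toward compound 3 are a 2.0-fold higher number from compound 1 to compound 3 (0.31 log units; beyond the scatter) and a 1.9-fold higher number from compound 2 to compound 3 (0.27 log units; within the scatter). Compound 4 `O=C(CSc1nc(Nc2ccccc2)c2ccccc2n1)Nc1ccc(Br)cc1` differs from compound 3 in this way: 4-bromophenyl in place of 3-methoxyphenyl on an amide-type nitrogen. Both measured steps that exchange a halophenyl for the 3-methoxyphenyl raised the number by roughly the same small amount, so the reverse exchange here is expected to lower it modestly, by a 1.8-fold lower number from compound 3 to compound 4 (0.27 log units; within the scatter), with the caveat that neither measured halophenyl is the 4-bromophenyl itself. Compound 4 is therefore expected to give about 10500 nM in this assay, within 5000 nM to 24000 nM.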

Compound 4, half-maximal inhibitory concentration: 10600 nM
The estimate for compound 4 lay 1.0-fold (0.00 log units) below the measured number, within the range that was stated.
By their numbers in this assay, from the lowest: compounds 1, 2, 4 and 3 (each within the scatter of the next, the first and the last beyond it).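

In this assay, among these compounds, moving the bromine on the phenyl ring of the amide yields no step that can be told from the scatter, with 4-bromophenyl in place of 2-bromophenyl giving a 1.0-fold higher number from compound 2 to compound 4 (0.01 log units; within the scatter). The other exchanges give a 1.1-fold higher number from compound 1 to compound 4 (0.04 log units; within the scatter) and a 1.8-fold lower number from compound 3 to compound 4 (0.26 log units; within the scatter), so compound 4 stays within the scatter of all three earlier compounds. No measurement shown here accounts for these steps.

As far as these compounds go, what remains open is whether an amine, a carboxylic acid or a longer chain in place of the aryl group on the amide-type nitrogen would give a step beyond the scatter.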